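From Cyclohexyl to Hexyl on the Carbonyl Carbon

The compounds below may be only part of what the source reports. "The series", "measured", "known", "first", "only" and "open" are said of these compounds alone.

Measured so far:
Compound 1 `CC(C)(C)N(NC(=O)c1ccccc1)C(=O)c1ccccc1I` gives 105 nM in an assay on cells for agonist activity at ecdysone receptor (Bombyx mori), read by a luciferase reporter, with a stated time of 24 h; a lower number here means that less compound is needed, a higher number that more compound is needed for the effect.
Compound 2 `CC(C)(C)N(NC(=O)c1ccccc1)C(=O)C1CCCCC1` gives 46800 nM in this assay.

For the measured compounds named here, compound 2 stands as the highest of the two numbers so far; its nearest neighbour is compound 1, and the step of a 450-fold higher number from compound 1 to compound 2 (2.65 log units; beyond the scatter) took the series from the lower number to the higher one by exchanging the 2-iodophenyl for a cyclohexyl.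

Compound 3 `CCCCCCC(=O)N(NC(=O)c1ccccc1)C(C)(C)C` is the next compound in this line. Its difference from compound 2 is hexyl in place of cyclohexyl on a carbonyl carbon. Going by the values given here, no measured step of the same kind exists: the only step known, from compound 1 to compound 2, concerns an aromatic group giving way to a saturated ring, and it was large. It shows that the carbonyl carbon is a position where changes matter, but it gives no direct reading of a ring opened into a chain.

Compound 3 is therefore expected to stay near compound 2 or to move to a somewhat higher number, with the step of a 1.9-fold higher number from compound 2 to compound 3 (0.28 log units; within the scatter) estimated as the likely outcome. The estimate for compound 3 is 90000 nM, within a range from 20000 nM to 400000 nM.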

Compound 3, half-maximal effective concentration: 7240 nM
Compound 3: middle estimate off by 12-fold (1.09 log units), on the high side; measured number outside the range, below it.
By their numbers in this assay, from the lowest: compound 1; then compound 3; then compound 2.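

Opening the saturated ring into a chain on the carbonyl carbon lowers the number in this assay (a 6.5-fold lower number from compound 2 to compound 3 (0.81 log units; beyond the scatter)), although cyclohexyl and hexyl have the same count of carbon atoms, so at this position two saturated groups of equal size by that count are not interchangeable. The earlier step (a 450-fold higher number from compound 1 to compound 2 (2.65 log units; beyond the scatter)) could not show this, as it changed an aromatic group for a saturated ring, while the hexyl group now recovers only part of that loss and remains well short of the 2-iodophenyl group (a 69-fold higher number from compound 1 to compound 3 (1.84 log units; beyond the scatter)), leaving compound 1 with the lowest number of the three. Nothing available here accounts for the difference between ring and chain.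

The compounds shown leave open whether the number would keep falling with a longer chain such as octyl or would rise with a shorter one such as propyl, as a single chain length gives no trend. They also leave open how much of the low number of compound 1 belongs to the iodine and how much to the phenyl ring, a question that a plain phenyl group on the carbonyl carbon would address.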